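Capping the oxygen: working notes on compound 4

The source may report more compounds than this note shows. Statements on the series, on what has been measured and on what is new or still open speak of the compounds shown alone.

Measured in a functional assay on HepG2 cells (Homo sapiens) for cytotoxicity, read by MTT assay; a higher number here means a weaker inhibitor, a lower number a stronger inhibitor:
- compound 1 `COc1ccc(/C=C/C(=O)c2ccc(OC)c3c2OC(C)(C)C=C3)cc1O`: 450 nM
- compound 2 `COc1ccc(/C=C/C(=O)c2ccc(OC)c3c2OC(C)(C)C=C3)cc1OCC=C(C)C`: > 10000 nM, a limit of the assay
- compound 3 `COc1ccc(/C=C/C(=O)c2ccc(OC)c3c2OC(C)(C)C=C3)cc1OCCCN(C)C`: 5550 nM

Compound 3 holds the higher of the two exact numbers, and the step to it is a 12-fold higher number from compound 1 to compound 3 (1.09 log units; beyond the scatter). Compound 4 `COc1ccc(/C=C/C(=O)c2ccc(OC)c3c2OC(C)(C)C=C3)cc1OC(=O)CCl` is still unmeasured, and the change is (chloromethyl)carbonyl in place of 3-(dimethylamino)propyl on an oxygen on an aromatic ring. Two large steps bear on it, both replacing the hydrogen on that oxygen: an at least 22-fold higher number from compound 1 to compound 2 (1.34 log units; beyond the scatter), and a 12-fold higher number from compound 1 to compound 3 (1.09 log units; beyond the scatter). The remaining step, an at least 1.8-fold lower number from compound 2 to compound 3 (0.25 log units; that floor lies within the scatter), separates the two substituents only weakly. Compound 4 also lacks that hydrogen, so a number nearer compound 3 at 5550 nM than compound 1 at 450 nM is expected. The expected change, slightly downward and not clearly beyond the scatter, is a 1.9-fold lower number from compound 3 to compound 4 (0.27 log units; within the scatter). For compound 4 the estimate is 3000 nM, with an expected range of 700 nM to 10000 nM.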

Compound 4, half-maximal inhibitory concentration: 120 nM
Estimate against measurement, compound 4: 25-fold (1.40 log units) above; measured number outside the range, below it.
By their numbers in this assay, from the lowest: compound 4; then compound 1; then compound 3. At a limit, above all of these: compound 2.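

Removing the hydrogen on this oxygen does not by itself raise the number: with (chloromethyl)carbonyl there, the result is a 3.8-fold lower number from compound 1 to compound 4 (0.57 log units; beyond the scatter), opposite in direction to the two earlier capped compounds. What is attached to the oxygen therefore decides the outcome, as a 46-fold lower number from compound 3 to compound 4 (1.67 log units; beyond the scatter) shows. The step of an at least 83-fold lower number from compound 2 to compound 4 (1.92 log units; beyond the scatter) is only a floor, since the value of compound 2 is a limit of the assay: the limit of > 10000 nM in this assay, at which 1 of the 4 values shown sits.

The compounds shown leave open whether the chlorine is needed. A plain acetyl group or a longer acyl chain on the same oxygen would test this.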